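This account rests on a few compounds, and the source may have more. Where it says the series, first, only, none or still open, it means among the compounds named here.

Measured so far:
- compound 1, `N[C@]1(C(=O)O)[C@H]2[C@@H](C[C@H]1OCc1cccc(C(F)(F)F)c1)[C@]2(F)C(=O)O`, gives 5.72 nM
- compound 2, `N#Cc1cccc(CO[C@@H]2C[C@@H]3[C@H]([C@]2(N)C(=O)O)[C@@]3(F)C(=O)O)c1`, gives 2.94 nM
- compound 3, `N[C@]1(C(=O)O)[C@H]2[C@@H](C[C@H]1OCc1cccc(-c3ccccc3)c1)[C@]2(F)C(=O)O`, gives 9.34 nM

These three share one core and differ only in the group on the benzyl ring. In an assay on CHO cells for binding affinity to metabotropic glutamate receptor 2 (Rattus norvegicus) (a higher number here means a weaker inhibitor, a lower number a stronger inhibitor), compound 3 has the highest number of the three: the step of a 1.6-fold higher number from compound 1 to compound 3 (0.21 log units; within the scatter) is small, but the step of a 3.2-fold higher number from compound 2 to compound 3 (0.50 log units; beyond the scatter) is real. Compound 4, `N[C@]1(C(=O)O)[C@H]2[C@@H](C[C@H]1OCc1cccc([N+](=O)[O-])c1)[C@]2(F)C(=O)O`, is made from compound 3 by the change (nitro in place of phenyl on an aromatic carbon), the new group sitting on an aromatic carbon meta to a large group. Among the measured compounds shown here, the only measured steps that bear on this are those in which the phenyl enters or leaves: a 3.2-fold higher number from compound 2 to compound 3 (0.50 log units; beyond the scatter) and a 1.6-fold higher number from compound 1 to compound 3 (0.21 log units; within the scatter). A nitro group resembles a cyano group more than a phenyl in size and in hydrogen-bond acceptors, so compound 4 is expected to move back toward the numbers of compound 1 and compound 2, giving a lower number by roughly a 2.3-fold lower number from compound 3 to compound 4 (0.37 log units; beyond the scatter). For compound 4 the estimate in this assay is therefore 4 nM, with a likely range from 1.5 nM to 11 nM.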

Compound 4, inhibition constant: 7.87 nM
Compound 4: middle estimate off by 2.0-fold (0.29 log units), on the low side, and the stated range covers the measured number.
By their numbers in this assay, from the lowest: compounds 2, 1, 4 and 3 (each within the scatter of the next, the first and the last beyond it).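

At this aromatic carbon, meta to a large group, this assay does not separate nitro from phenyl (a 1.2-fold lower number from compound 3 to compound 4 (0.07 log units; within the scatter)), even though phenyl is a carbon ring without hydrogen-bond acceptors and nitro has no ring and carries such acceptors. Nitro also stays within the scatter of trifluoromethyl (a 1.4-fold higher number from compound 1 to compound 4 (0.14 log units; within the scatter)), but cyano differs from nitro (a 2.7-fold higher number from compound 2 to compound 4 (0.43 log units; beyond the scatter)) as it does from phenyl, so cyano is the only group here that stands apart from any other, and it does not stand apart from trifluoromethyl. No measurement available here explains these results.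

As far as these compounds go, whether an amine or a carboxylic acid on this carbon would stay close to these numbers remains open. So does whether a longer chain would be accepted here.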